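The compounds below may be only part of what the source reports. "The series", "measured", "known", "first", "only" and "open" are said of these compounds alone.

Measured compounds:
- compound 1 `N/C(=N/O)c1ccc(C2=C(S(=O)(=O)c3ccc(F)cc3)CC(c3ccccc3)(c3ccccc3)O2)cc1`: 10200 nM
- compound 2 `CC1(Cc2ccccc2)CC(S(=O)(=O)c2ccccc2F)=C(c2ccc(/C(N)=N\O)cc2)O1`: 29100 nM
- compound 3 `CCC1(c2ccccc2OC)CC(S(=O)(=O)c2ccc(F)cc2)=C(c2ccc(/C(N)=N\O)cc2)O1`: 9880 nM

Working notes on the series. The read-out is an ADME assay on J774.A1 cells (Mus musculus) for cytotoxicity, read by MTT assay, with a stated time of 72 h; on this read-out higher numbers stand for lower toxicity in this test and lower numbers for higher toxicity in this test. In this assay compound 1 gives 10200 nM, the second highest of the three numbers. Its nearest neighbour is compound 3, which gives 9880 nM, a gap within the usual scatter, so the two cannot be ordered. Compound 2 gives 29100 nM, the highest number of the set, and its gap to compound 1 lies beyond the scatter.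

Compound 4 `COc1ccc(C2(c3ccccc3)CC(S(=O)(=O)c3ccc(F)cc3)=C(c3ccc(/C(N)=N\O)cc3)O2)cc1` is not yet measured. It differs from compound 1 by methoxy in place of hydrogen on an aromatic carbon. Within the data shown here, no pair of measured compounds shows this single change, so the size of the step has no precedent; the three measured numbers sit in a narrow band, and no step beyond the scatter is expected from compound 1 to compound 4 in this assay. The estimate for compound 4 is 11000 nM, with a range from 5000 nM to 25000 nM, corresponding to an expected step of a 1.1-fold higher number from compound 1 to compound 4 (0.03 log units; within the scatter).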

Compound 4, half-maximal cytotoxic concentration: 11300 nM
For compound 4 the middle estimate is 1.0-fold (0.01 log units) below the measured one; the measured number falls inside the stated range.
By their numbers in this assay, from the lowest: compounds 3, 1 and 4 (each within the scatter of the next); then compound 2.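

In this assay, among these compounds, the change from phenyl to 4-methoxyphenyl gives a 1.1-fold higher number from compound 1 to compound 4 (0.04 log units; within the scatter) and is the first single-place step that can be read. Among the compounds shown here, at this position, on an aromatic carbon para to a large group, the methoxy group therefore leaves the read-out unable to separate the two compounds, something the earlier compounds, which differ in several places, could not show. No measurement at hand speaks to the reason for this result.

As far as these compounds go, whether an amine, a carboxylic acid or a longer chain such as butoxy at the same position would also stay within the scatter of compound 1 remains open. So does whether methoxy on another carbon of this ring, or on the second phenyl ring, would give a similarly small step.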